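This account rests on a few compounds, and the source may have more. Where it says the series, first, only, none or still open, it means among the compounds named here.

Measured compounds:
Compound 1 `Cn1c(N)c(-c2nc3ccccc3[nH]2)c2nc(C#N)c(C#N)nc21`: in a functional assay on cells (Homo sapiens) for antiproliferative activity, read by MTT assay, with a stated time of 48 h (on this read-out higher numbers stand for weaker inhibition and lower numbers for stronger inhibition), compound 1 gives only the assay limit > 50000 nM.
Compound 2 `CCn1c(N)c(-c2nc3ccccc3[nH]2)c2nc(C#N)c(C#N)nc21`: in this assay compound 2 likewise gives only the limit > 50000 nM.
Compound 3 `CN(C)CCn1c(N)c(-c2nc3ccccc3[nH]2)c2nc(C#N)c(C#N)nc21`: in this assay compound 3 gives 43500 nM, the only number shown. Both other values sit at the limit of > 50000 nM in this assay, at which 2 of the 3 values shown sit.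

Compound 4 `N#Cc1nc2c(-c3nc4ccccc4[nH]3)c(N)n(CCCO)c2nc1C#N` differs from compound 3 by hydroxymethyl in place of dimethylamino on a saturated chain carbon, two bonds along the chain from an aromatic nitrogen. The steps that touch this position are an at least 1.1-fold lower number from compound 2 to compound 3 (0.06 log units; that floor lies within the scatter) and an at least 1.1-fold lower number from compound 1 to compound 3 (0.06 log units; that floor lies within the scatter), both floors inside the scatter, while a step that the two limits leave unreadable from compound 1 to compound 2. Nothing here separates substituents on the chain at the aromatic nitrogen beyond the scatter, so in this assay no step beyond the scatter is expected, with an estimated 1.0-fold higher number from compound 3 to compound 4 (0.01 log units; within the scatter). Compound 4 is therefore estimated at 45000 nM, between 18000 nM and 100000 nM, and a bare limit is quite possible.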

Compound 4, half-maximal inhibitory concentration: > 50000 nM
Compound 4: a limit, no number (the forecaster's own chance of this, stated with the estimate: 50%); at least 1.1-fold (0.04 log units) between middle value and limit.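

In this assay, among the compounds shown here, hydroxymethyl in place of dimethylamino on this chain gives an at least 1.1-fold higher number from compound 3 to compound 4 (0.06 log units; that floor lies within the scatter), so this change shows only a floor and no step of readable size. Compound 4 gives only a limit, and the readings now gather there: the limit of > 50000 nM in this assay, at which 3 of the 4 values shown sit. The steps to compound 4 from compound 1 and from compound 2 cannot be read, since both ends of each are limits.

As far as these compounds go, whether the dimethylamino group matters at all remains open. Also open, from the compounds shown here alone, is what a longer chain, a morpholine or a carboxylic acid would give at this position.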